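Working notes on four compounds: one methyl step, one estimate

This account rests on a few compounds, and the source may have more. Where it says the series, first, only, none or still open, it means among the compounds named here.

Measured in an ADME assay on Caco-2 cells (Homo sapiens) for permeability, read by LC-MS, with a stated time of 2 h; on this read-out higher numbers stand for higher permeability and lower numbers for lower permeability:
- compound 1 `Cc1cc(CN(CC2CCCC2)[C@@H](CC(=O)O)c2ccc(Cl)cc2)ccc1OCCN1C(=O)CCC1=O`: 18.1 nm/s
- compound 2 `CCN(Cc1ccc(OCCn2c(=O)ccn(C)c2=O)c(C)c1)C(CC(=O)O)c1ccc(Cl)cc1`: 2.1 nm/s
- compound 3 `CCCN(Cc1ccc(OCCn2c(=O)ccn(C)c2=O)c(C)c1)C(CC(=O)O)c1ccc(Cl)cc1`: 3.2 nm/s

Compound 2 and compound 3 share one core and differ in a single place. Compound 1 rests on a different core; the difference between the two cores is not broken down here. In this assay compound 1 gives the highest of the three numbers, and its distance to both compound 2 and compound 3 lies beyond the usual scatter.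

Within the data shown here, the one counted step among the measured compounds is methyl in place of hydrogen on a saturated chain carbon, two bonds along the chain from an amine nitrogen, which gave a 1.5-fold higher number from compound 2 to compound 3 (0.18 log units; within the scatter).

Compound 4 `CCc1cc(CN(CC2CCCC2)[C@@H](CC(=O)O)c2ccc(Cl)cc2)ccc1OCCN1C(=O)CCC1=O` is not yet measured. It differs from compound 1 by methyl in place of hydrogen on a saturated chain carbon bound to an aromatic carbon. Among the measured compounds shown here, this is the same kind of change as the one from compound 2 to compound 3, not the same change: in compound 4 the new methyl sits on a saturated chain carbon bound to an aromatic carbon, whereas in compound 3 it sits on a saturated chain carbon, two bonds along the chain from an amine nitrogen.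

With that reservation, the expectation for compound 4 rests on the observation that the same kind of methyl-for-hydrogen step gave only a 1.5-fold higher number from compound 2 to compound 3 (0.18 log units; within the scatter), a move within the scatter. The step from compound 1 is therefore expected to be a 1.1-fold higher number from compound 1 to compound 4 (0.04 log units; within the scatter). Compound 4 is expected to give about 20 nm/s in this assay, with the plausible range running from 9 nm/s to 45 nm/s.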

Compound 4, apparent permeability: 57.3 nm/s
Estimate against measurement, compound 4: 2.9-fold (0.46 log units) below; the measured number lies above the stated range.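

In this assay the methyl-for-hydrogen change can be read on two cores, and the two steps do not separate: the same change on two cores in this assay, a 1.5-fold higher number (0.18 log units; within the scatter) from compound 2 to compound 3 and a 3.2-fold higher number (0.50 log units; beyond the scatter) from compound 1 to compound 4, 2.1-fold (0.32 log units) apart, within the scatter of two such steps

Read singly, the step on the core of compound 1 is a 3.2-fold higher number from compound 1 to compound 4 (0.50 log units; beyond the scatter), whereas the step on the other core is a 1.5-fold higher number from compound 2 to compound 3 (0.18 log units; within the scatter), so only the first stands clear of the scatter. Among these compounds, this does not show that the size of the step holds across the series: there are only two pairs, and the new methyl sits in a different place in each, on a saturated chain carbon bound to an aromatic carbon in compound 4 and on a saturated chain carbon, two bonds along the chain from an amine nitrogen, in compound 3, so the effect of the core cannot be told apart from that of the place.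

The compounds shown leave open what the same methyl-for-hydrogen change does at the same place on both cores. They also leave open how a longer chain than the ethyl of compound 4, or a methoxy group or a fluorine in that place, would read on the core of compound 1.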